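Replacing 4-hydroxy-3-methoxyphenyl with 4-methylphenyl

The source may hold more compounds than are shown below. What is called first, only, known or untested is meant among the compounds shown, and "the series" means these compounds.

Measured in a physicochemical assay for lipophilicity; on this read-out lower numbers stand for lower lipophilicity and higher numbers for higher lipophilicity:
- compound 1 `C[C@H]1CC[C@@H]2[C@@H](OC(=O)[C@]23CC(c2ccccc2Br)=NO3)[C@]2(C)C(=O)C=C[C@@]12O`: 2.22
- compound 2 `COc1cc(C2=NO[C@]3(C2)C(=O)O[C@@H]2[C@H]3CC[C@H](C)[C@]3(O)C=CC(=O)[C@@]23C)ccc1O`: 0.75

Compound 2, at 0.75, holds the lower of the two numbers in this assay, and compound 1 gives 2.22.

The next compound to be measured is compound 3 `Cc1ccc(C2=NO[C@]3(C2)C(=O)O[C@@H]2[C@H]3CC[C@H](C)[C@]3(O)C=CC(=O)[C@@]23C)cc1`. The change is 4-methylphenyl in place of 4-hydroxy-3-methoxyphenyl on a carbon with a double bond to nitrogen, with 4-methylphenyl in place of 4-hydroxy-3-methoxyphenyl on a carbon with a double bond to nitrogen.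

For the measured compounds named here, one measured step bears on this: a number 1.47 log units lower from compound 1 to compound 2 (beyond the scatter). In that large step, beyond the scatter, 4-hydroxy-3-methoxyphenyl entered in place of 2-bromophenyl at this same carbon. The group that entered there now leaves. Going by the values given here, no measured compound carries 4-methylphenyl, so the expectation rests on this single step and on the structural change.

A large rise in this assay is expected, of somewhat smaller size than the measured step in the opposite direction. The expected change is a number 1.25 log units higher from compound 2 to compound 3 (beyond the scatter). Compound 3 is estimated at 2, with an expected range from 1.5 to 2.5.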

Compound 3, partition coefficient: 1.86
For compound 3 the middle estimate is 0.14 log units above the measured one, and the stated range covers the measured number.
By their numbers in this assay, from the lowest: compound 2; then compound 3; then compound 1.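

In this assay the group on the carbon with a double bond to nitrogen now has a second measured change: 4-methylphenyl in place of 4-hydroxy-3-methoxyphenyl gives a number 1.11 log units higher from compound 2 to compound 3 (beyond the scatter) as a large step beyond the scatter. The third comparison at this place, a number 0.36 log units lower from compound 1 to compound 3 (beyond the scatter) with 4-methylphenyl in place of 2-bromophenyl, is also beyond the scatter but only modest, so the three groups do not fall at even intervals: 4-methylphenyl stands much closer to 2-bromophenyl than to 4-hydroxy-3-methoxyphenyl. No independent data accompany these numbers to account for the differences.

The step from compound 2 to compound 3 removes the hydroxy and methoxy groups and adds the methyl group all at once, so the shares of these changes stay unresolved; 4-hydroxyphenyl and 3-methoxyphenyl on the same carbon would separate the first two. The compounds shown also leave open how an aminophenyl or carboxyphenyl group at this place would stand against these three, and whether 4-bromophenyl would fall near 2-bromophenyl or 4-methylphenyl on this read-out.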